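A few compounds are considered here, and "the series" means these few. Any claim that something is new, unique, unknown or untested is made for them only; others in the source may bear on it.

In a functional assay on PC-3 cells (Homo sapiens) for cytotoxicity, read by sulforhodamine B assay, with a stated time of 72 h (a higher number here means a weaker inhibitor of growth, a lower number a stronger inhibitor of growth), compound 1 `CC(=O)N1c2ccccc2CCC1C(=O)Nc1ccccc1O` gives 70700 nM, the higher of the two numbers recorded. Among the measured compounds shown here, compound 2 `CCCC(=O)N1c2ccccc2CCC1C(=O)Nc1cc(C(F)(F)F)cc(C(F)(F)F)c1` gives 18600 nM, a gap beyond the scatter, but it differs from compound 1 in two places, so no single step links them. Compound 3 `CC(=O)N1c2ccccc2CCC1C(=O)Nc1ccccc1C(F)(F)F` is recorded only as a limit of the assay, > 80000 nM, the limit set out as the limit of > 80000 nM in this assay, at which 1 of the 3 values shown sits. The step of an at least 1.1-fold higher number from compound 1 to compound 3 (0.05 log units; that floor lies within the scatter) alters a group on an aromatic carbon and stays within the scatter. Compound 4 `O=C(Nc1ccccc1O)C1CCc2ccccc2N1C(=O)c1cccc(Cl)c1` differs from compound 1 by 3-chlorophenyl in place of methyl on a carbonyl carbon. For the measured compounds named here, no measured step changes this carbonyl alone, so the direction is open. Compound 4 is expected to give 35000 nM, within 9000 nM to 80000 nM, an estimated step of a 2.0-fold lower number from compound 1 to compound 4 (0.31 log units; beyond the scatter).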

Compound 4, concentration for 50% growth inhibition: 23300 nM
Estimate against measurement, compound 4: 1.5-fold (0.18 log units) above; the range from low to high includes it.
By their numbers in this assay, from the lowest: compounds 2 and 4 (each within the scatter of the next); then compound 1. At a limit, above all of these: compound 3.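

In this assay, changing acetyl to (3-chlorophenyl)carbonyl gives a 3.0-fold lower number from compound 1 to compound 4 (0.48 log units; beyond the scatter). This is the first step shown that changes the group on this carbonyl carbon and the first to lie beyond the scatter, so a chlorinated aromatic ring here gives stronger growth inhibition than methyl does. No measured property accounts for this change. A single step cannot separate the contribution of the ring from that of its chlorine. On these data alone, whether plain phenyl or an amine on this carbonyl carbon would behave the same also remains open.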